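A Heteroaromatic Ring Replaces Chlorophenyl on the Amide Nitrogen

The compounds below may be only part of what the source reports. "The series", "measured", "known", "first", "only" and "open" are said of these compounds alone.

Of the compounds shown here, three on one shared core have been measured in a physicochemical assay for lipophilicity, read by HPLC, in phosphate buffer, measured as chromatographic lipophilicity, at pH 7.4; a lower number here means a more polar compound, a higher number a more lipophilic compound. Compound 1 `COc1ccc2nc(C)cc(OCC(=O)Nc3cc(C)ccc3C)c2c1` gives 5.05, compound 2 `COc1ccc2nc(C)cc(OCC(=O)Nc3cc(C)c(F)c(C)c3)c2c1` gives 5.5, and compound 3 `COc1ccc2nc(C)cc(OCC(=O)Nc3ccc(Cl)cc3)c2c1` gives 5.15, the second highest of the three, within the scatter of compound 1 but separated by a step beyond the scatter, a number 0.35 log units lower from compound 2 to compound 3 (beyond the scatter). Compound 4 `COc1ccc2nc(C)cc(OCC(=O)Nc3noc(C)c3C)c2c1` differs from compound 3 in one place: 4,5-dimethyl-1,2-oxazol-3-yl in place of 4-chlorophenyl on an amide-type nitrogen. The measured steps, a number 0.45 log units higher from compound 1 to compound 2 (beyond the scatter) and a number 0.10 log units higher from compound 1 to compound 3 (within the scatter), each exchange one carbon-only ring for another and so bear only loosely on this change, in which a ring with hetero atoms and hydrogen-bond acceptors enters where the leaving ring carried none. A drop beyond the scatter is therefore expected. Compound 4 is estimated at 4, between 3.4 and 4.6. This corresponds to an expected step of a number 1.15 log units lower from compound 3 to compound 4 (beyond the scatter).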

Compound 4, distribution coefficient: 3.3
Beside the measured number, compound 4's estimate is 0.70 log units above it; measured number outside the range, below it.
By their numbers in this assay, from the lowest: compound 4; then compounds 1 and 3 (each within the scatter of the next); then compound 2.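

In this assay the three steps to the 4,5-dimethyl-1,2-oxazol-3-yl group are a number 1.85 log units lower from compound 3 to compound 4 (beyond the scatter) and a number 1.75 log units lower from compound 1 to compound 4 (beyond the scatter) and a number 2.20 log units lower from compound 2 to compound 4 (beyond the scatter), each larger than any step among the carbon-only rings, so this place on the amide-type nitrogen can shift the number further than those rings showed. The leaving 4-chlorophenyl and the entering group have the same heavy-atom count and no net charge, so atom count does not separate them. Nothing measured here explains the size of this drop. As far as these compounds go, it remains open whether a pyridyl ring, which keeps six ring members but holds a ring nitrogen, would give a drop of this size or whether the five-membered ring is needed.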